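The source may hold more compounds than are shown below. What is called first, only, known or untested is meant among the compounds shown, and "the series" means these compounds.

Going by the values given here, compound 2 `Clc1cccc(-c2nc(N3CCCCC3)c3nc[nH]c3n2)c1` gives 50.1 nM in an assay on cells for displacement of a labelled ligand from adenosine receptor A1 (Homo sapiens), read by scintillation counting and radioligand binding, with a stated time of 60 min (a lower number here means a stronger inhibitor, a higher number a weaker inhibitor), the lowest of the two numbers so far. Compound 1 `Clc1ccc(-c2nc(N3CCCCC3)c3nc[nH]c3n2)cc1` gives 126 nM in this assay, and a 2.5-fold lower number from compound 1 to compound 2 (0.40 log units; beyond the scatter). Compound 3 `Oc1ccc(-c2nc(N3CCCCC3)c3nc[nH]c3n2)cc1` differs from compound 2 by 4-hydroxyphenyl in place of 3-chlorophenyl on an aromatic carbon. Among the compounds with values here, the one measured step changed where the chlorine sits rather than exchanging it for a hydroxy group, so it bears only loosely on this change, and the direction is uncertain. Compound 3 is therefore expected to come out near compound 2 or somewhat weaker, an expected step of a 4.0-fold higher number from compound 2 to compound 3 (0.60 log units; beyond the scatter). The estimate for compound 3 is 200 nM, ranging from 40 nM to 1000 nM.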

Compound 3, inhibition constant: 10 nM
Beside the measured number, compound 3's estimate is 20-fold (1.30 log units) above it, and the stated range ends above it.
By their numbers in this assay, from the lowest: compound 3; then compound 2; then compound 1.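

Until now only the chlorine had moved; this result shows that the choice of group on the phenyl ring matters too. With the group kept in the same ring position in this assay, hydroxy in place of chloro gives a 13-fold lower number from compound 1 to compound 3 (1.10 log units; beyond the scatter) and is a large step, while 4-hydroxyphenyl also improves on the better chlorine placement, with a 5.0-fold lower number from compound 2 to compound 3 (0.70 log units; beyond the scatter) as the result. Nothing available explains why the number falls.

Open, going by these compounds, is whether 3-hydroxyphenyl would do better still. Also open, on these data alone, is whether a methoxy group, an amine or a carboxylic acid in place of the hydroxy would keep this strength.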